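Cinnamamide aryl swap: from compound 2 to compound 4

The source may hold more compounds than are shown below. What is called first, only, known or untested is meant among the compounds shown, and "the series" means these compounds.

Measured compounds:
- compound 1 `COc1ccc(C(=O)c2cc(OC)c(OC)c(OC)c2)cc1N`, in a functional assay on DU-145 cells (Homo sapiens) for cytotoxicity, read by MTT assay, with a stated time of 72 h (a higher number here means a weaker inhibitor, a lower number a stronger inhibitor), compound 1 gives 2100 nM
- compound 2 `COc1ccc(C(=O)c2cc(OC)c(OC)c(OC)c2)cc1NC(=O)/C=C/c1cc(OC)c(OC)c(OC)c1`, in this assay compound 2 gives 6300 nM
- compound 3 `COc1ccc(C(=O)c2cc(OC)c(OC)c(OC)c2)cc1NC(=O)/C=C/c1ccc(OC)c(OC)c1`, in this assay compound 3 gives 10200 nM

Compound 2 stands second highest of the three numbers in this assay. Its nearest neighbour is compound 3, reached by a 1.6-fold higher number from compound 2 to compound 3 (0.21 log units; within the scatter), a step within the scatter. For the measured compounds named here, the gap to compound 1 lies beyond the scatter, and compound 1 has the lower number of the two; no single-point step connects compound 1 and compound 2, so only their two values are on record.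

Compound 4 `C#CCOc1cccc(/C=C/C(=O)Nc2cc(C(=O)c3cc(OC)c(OC)c(OC)c3)ccc2OC)c1` differs from compound 2 in one place: 3-(propargyloxy)phenyl in place of 3,4,5-trimethoxyphenyl on a double-bonded chain carbon bound to a double-bonded chain carbon. Going by the values given here, the only measured step that touches the same aryl group is the one from compound 2 to compound 3, where one methoxy was taken away and the number in this assay moved only within the scatter. Among the compounds with values here, compound 4 goes further, removing two methoxy groups and changing the third to propargyloxy, for which no precedent is on record here. Taking the one step that bears on it as the guide, a small move upward in this assay, or none beyond the scatter, is expected; the step from compound 2 to compound 4 is estimated as a 1.4-fold higher number from compound 2 to compound 4 (0.15 log units; within the scatter). For compound 4 the expected value in this assay is 9000 nM, with a range from 3500 nM to 25000 nM.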

Compound 4, half-maximal inhibitory concentration: 15800 nM
Compound 4: the middle estimate sits 1.8-fold (0.24 log units) below what was measured, within the range that was stated.
By their numbers in this assay, from the lowest: compound 1; then compounds 2, 3 and 4 (each within the scatter of the next, the first and the last beyond it).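

In this assay, the aryl group on a double-bonded chain carbon bound to a double-bonded chain carbon now has a change that clears the scatter: 3-(propargyloxy)phenyl in place of 3,4,5-trimethoxyphenyl gives a 2.5-fold higher number from compound 2 to compound 4 (0.40 log units; beyond the scatter), whereas the earlier loss of one methoxy gave only a 1.6-fold higher number from compound 2 to compound 3 (0.21 log units; within the scatter). Measured against 3,4-dimethoxyphenyl, the same group gives a 1.5-fold higher number from compound 3 to compound 4 (0.19 log units; within the scatter), so compound 3 and compound 4 cannot be separated, and the position accepts a group with a triple bond and a single hydrogen-bond acceptor at the cost of a modest step from the trimethoxy compound only. Nothing on record gives a measured basis for that step.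

Compound 4 changes the methoxy groups and brings in the propargyloxy group in a single move, so the compounds shown cannot apportion the step between the lost methoxy groups and the triple bond. Going by these compounds, a plain phenyl or a 3-methoxyphenyl would divide those two contributions, and how this position responds to an amine or a carboxylic acid on the ring remains open.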